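Halogen swap on the pyridyl arm: chloro to bromo

The compounds below may be only part of what the source reports. "The series", "measured", "known", "first", "only" and "open" are said of these compounds alone.

Measured so far in a functional assay on cells for inhibition of Polyunsaturated fatty acid 5-lipoxygenase (Homo sapiens); a higher number here means a weaker inhibitor, a lower number a stronger inhibitor:
- compound 1 `O=C1NCCN(c2ccccn2)N1` — 8600 nM
- compound 2 `O=C1NCCN(c2cccc(Cl)n2)N1` — 4800 nM
- compound 3 `CC1CN(c2cccc(Cl)n2)NC(=O)N1` — 1600 nM

Compound 2 sits second highest of the three numbers. Its nearest neighbour is compound 1, separated by a 1.8-fold lower number from compound 1 to compound 2 (0.25 log units; within the scatter), a gap that stays within the scatter. The furthest is compound 3, reached by a 3.0-fold lower number from compound 2 to compound 3 (0.48 log units; beyond the scatter), a modest but real step that comes from the methyl on the saturated ring carbon, not from the aromatic side.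

Compound 4 `O=C1NCCN(c2cccc(Br)n2)N1` is the next member. Against compound 2 the change is bromo in place of chloro on an aromatic carbon. Going by the values given here, only one measured step touches the same aromatic position, and that is a 1.8-fold lower number from compound 1 to compound 2 (0.25 log units; within the scatter), the introduction of the chloro itself, which did not move the number beyond the scatter. Among the compounds with values here, no bromo analogue exists in the set, so the exchange of one halogen for another has no direct precedent here; the closest evidence says this position is not very sensitive. The expectation is therefore a step of about a 1.2-fold lower number from compound 2 to compound 4 (0.08 log units; within the scatter), that is, no change beyond the scatter, with a wide range to allow for the untested halogen. Compound 4 is estimated at 4000 nM, with a range from 1800 nM to 9000 nM.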

Compound 4, half-maximal inhibitory concentration: 4600 nM
Beside the measured number, compound 4's estimate is 1.2-fold (0.06 log units) below it, and the stated range covers the measured number.
By their numbers in this assay, from the lowest: compound 3; then compounds 4, 2 and 1 (each within the scatter of the next).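

In this assay, bromo in place of chloro on this aromatic carbon gives a 1.0-fold lower number from compound 2 to compound 4 (0.02 log units; within the scatter) and so leaves the number unchanged within the scatter, which shows that the two halogens cannot be told apart at this position in the series. Bromo in place of hydrogen on the same carbon gives a 1.9-fold lower number from compound 1 to compound 4 (0.27 log units; within the scatter) as its step, so a second halogen, like chloro before it, stays within the scatter of the unsubstituted compound 1. Nothing available explains this result.

Still open, from the compounds shown here alone, is whether the methyl on the saturated ring carbon, which gives a 3.0-fold lower number from compound 2 to compound 3 (0.48 log units; beyond the scatter) as its step with chloro on the aromatic ring, would give a comparable step with bromo in that place. Also open is whether a group other than a halogen on this aromatic carbon, such as a methoxy, a nitrile or an amine, would move the number beyond the scatter, since the compounds shown carry only hydrogen, chloro or bromo there.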